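This account rests on a few compounds, and the source may have more. Where it says the series, first, only, none or still open, it means among the compounds named here.

Working notes on the series. Compound 3 `NC(N)=NC(=O)c1nc(Cl)c(O)nc1N` stands lowest of the three measured compounds: in an assay for inhibition of acid-sensing ion channel 3 (Homo sapiens), read by patch clamp, tested at 20 uM (a lower number here means less inhibition, a higher number more inhibition at the concentration tested (going by the name of the read-out)), compound 3 gives 9%, while compound 1 `NC(N)=NC(=O)c1nc(Cl)c(NC2CC2)nc1N` gives 78% and compound 2 `NC(N)=NC(=O)c1nc(Cl)c(N2CCCC2)nc1N` gives 84%. Both drops onto compound 3 are large: a number 69 percentage points lower from compound 1 to compound 3 (beyond the scatter) and a number 75 percentage points lower from compound 2 to compound 3 (beyond the scatter), whereas a number 6 percentage points higher from compound 1 to compound 2 (within the scatter). Compound 4 `NC(N)=NC(=O)c1nc(Cl)c(Oc2ccccc2)nc1N` is the next entry; the change from compound 3 is phenyl in place of hydrogen on an oxygen on an aromatic ring. For the measured compounds named here, no measured step covers this change directly; the two steps to compound 3 only show that hydroxy sits far below the two amines in this assay. Compound 4 is therefore expected to move upward from compound 3, a number 31 percentage points higher from compound 3 to compound 4 (beyond the scatter), with wide uncertainty. The estimate for compound 4 in this assay is 40%, ranging from 10% to 70%.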

Compound 4, a percentage reported as inhibition, at one concentration (the size of the read-out at that concentration, not a potency): 90%
Estimate against measurement, compound 4: 50 percentage points below; the whole stated range lies below it.
By their numbers in this assay, from the lowest: compound 3; then compounds 1, 2 and 4 (each within the scatter of the next, the first and the last beyond it).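

In this assay, phenyl on the oxygen gives a number 81 percentage points higher from compound 3 to compound 4 (beyond the scatter), so an oxygen on this aromatic carbon does not in itself go with a low number. An amine at this position is not needed either: there is a number 6 percentage points higher from compound 2 to compound 4 (within the scatter), and a number 12 percentage points higher from compound 1 to compound 4 (beyond the scatter). Nothing available explains this result.

Open, on these data alone, is whether a smaller group on the same oxygen, such as methyl, stays with compound 4 or falls towards compound 3. Also open, as far as these compounds go, is how a phenyl ring carrying a chloro or methoxy group would read.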